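A few compounds are considered here, and "the series" means these few. Any claim that something is new, unique, unknown or untested is made for them only; others in the source may bear on it.

Compound 1 `CN(C)c1cccc(Oc2ccc3c(NCCCNCc4ccco4)ccnc3c2)c1`: 16000 nM
Compound 2 `COc1cccc(CNCCCNc2ccnc3cc(Oc4cccc(N(C)C)c4)ccc23)c1O`: 7300 nM

In an ADME assay on HepG2 cells (Homo sapiens) for cytotoxicity, read by luminescence, CellTiter-Glo and ATP content, with a stated time of 72 h (on this read-out higher numbers stand for an effect only at larger amounts of compound and lower numbers for an effect already at smaller amounts), compound 1 gives 16000 nM, the highest of the two numbers. The nearest is compound 2, which gives 7300 nM. The step between them is a 2.2-fold lower number from compound 1 to compound 2 (0.34 log units; beyond the scatter).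

Compound 3 `Fc1ccc(Cc2ccc3c(NCCCNCc4ccco4)ccnc3c2)c(Cl)c1` has not yet been measured. Its difference from compound 1 is 2-chloro-4-fluorobenzyl in place of 3-(dimethylamino)phenoxy on an aromatic carbon. Among the compounds with values here, no measured step touches this part of the molecule: the single known step, from compound 1 to compound 2, alters the group on the saturated chain carbon bound to an amine nitrogen, not the aromatic carbon of the fused ring system, and it was only modest. There is thus no basis for expecting a step beyond the scatter in this assay in either direction, and the uncertainty is wide. Compound 3 is expected to give about 12000 nM, within 4000 nM to 35000 nM, which would mean an estimated step of a 1.3-fold lower number from compound 1 to compound 3 (0.12 log units; within the scatter).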

Compound 3, half-maximal effective concentration: 5730 nM
The estimate for compound 3 lay 2.1-fold (0.32 log units) above the measured number; measured number inside the range.
By their numbers in this assay, from the lowest: compounds 3 and 2 (each within the scatter of the next); then compound 1.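

In this assay, the change on this aromatic carbon gives a 2.8-fold lower number from compound 1 to compound 3 (0.45 log units; beyond the scatter), so the number responds to this part of the molecule as well as to the group on the saturated chain carbon altered in compound 2. The swap changes several things at once: the group that leaves carries nitrogen, oxygen and hydrogen-bond acceptors, while the group that enters carries chlorine and fluorine and has no hydrogen-bond acceptors. No measurement at hand explains why the number moves with this swap.

Which of these differences carries the step stays open, and an unsubstituted benzyl or an unsubstituted phenoxy group at this position would help separate them. Also open, going by these compounds, is whether 2-chloro-4-fluorobenzyl gives a similar step when 2-hydroxy-3-methoxyphenyl stands in place of furan-2-yl.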